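Cytotoxicity of catechol vinyl sulfones with varied benzamide aryl groups

The compounds below may be only part of what the source reports. "The series", "measured", "known", "first", "only" and "open" are said of these compounds alone.

Compound 1 `CC(=O)Oc1ccc(/C=C/S(=O)(=O)CCc2ccc(NC(=O)c3ccc(C)cc3)cc2)cc1OC(C)=O`: 177000 nM
Compound 2 `O=C(Nc1ccc(CCS(=O)(=O)/C=C/c2ccc(O)c(O)c2)cc1)c1ccc(F)cc1`: limit, > 1000000 nM
Compound 3 `O=C(Nc1ccc(CCS(=O)(=O)/C=C/c2ccc(O)c(O)c2)cc1)c1cc(F)cc(F)c1`: 414000 nM

In an ADME assay on TZM cells (Homo sapiens) for cytotoxicity, read by CCK-8 assay, with a stated time of 2 days (a higher number here means that more compound is tolerated, a lower number that less compound is tolerated), compound 3 gives 414000 nM, the higher of the two numbers recorded; compound 1 sits at a 177000 nM. For compound 2 the assay gives only a limit, > 1000000 nM (the limit of > 1000000 nM in this assay, at which 1 of the 3 values shown sits). Going by the values given here, the one measured step, an at least 2.4-fold lower number from compound 2 to compound 3 (0.38 log units; beyond the scatter), shows that changing the aryl group on the carbonyl carbon can move the number beyond the scatter. Compound 4 `O=C(Nc1ccc(CCS(=O)(=O)/C=C/c2ccc(O)c(O)c2)cc1)c1ccc([N+](=O)[O-])cc1` carries 4-nitrophenyl in place of 3,5-difluorophenyl on a carbonyl carbon. Among the compounds with values here, no measured step covers a nitro group, so no direction can be drawn from the data; the step of a 1.2-fold higher number from compound 3 to compound 4 (0.08 log units; within the scatter) is therefore expected to stay within the scatter. Compound 4 is estimated at 500000 nM, between 180000 nM and 1400000 nM.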

Compound 4, half-maximal cytotoxic concentration: 483000 nM
Beside the measured number, compound 4's estimate is 1.0-fold (0.02 log units) above it; low and high end bracket the measured number.
By their numbers in this assay, from the lowest: compound 1; then compounds 3 and 4 (each within the scatter of the next). At a limit, above all of these: compound 2.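

Placing 4-nitrophenyl in place of 3,5-difluorophenyl on the carbonyl carbon gives a 1.2-fold higher number from compound 3 to compound 4 (0.07 log units; within the scatter), so in this assay these two aryl groups cannot be told apart. Nitro in place of fluoro on an aromatic carbon gives an at least 2.0-fold lower number from compound 2 to compound 4 (0.31 log units; beyond the scatter), which makes the 4-fluorophenyl group the one that stands apart from both other aryl groups among these three amides. That separation rests on a limit, not a number: the limit of > 1000000 nM in this assay, at which 1 of the 4 values shown sits. On these data alone, whether an amine or a carboxylic acid on this aryl ring would stay with compound 3 and compound 4 or move beyond the scatter remains open.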